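A few compounds are considered here, and "the series" means these few. Any claim that something is new, unique, unknown or untested is made for them only; others in the source may bear on it.

Measured so far:
compound 1 `[N-]=[N+]=NCC(O)Cn1c(=O)n(C2OC(CO)[C@@H](O)[C@H]2O)c2nc(N)nc(O)c21` gives 91% in a functional assay on the whole organism (B cells) with Mus musculus as the target; a higher number here means a larger maximal response, a lower number a smaller maximal response
compound 2 `C=CCn1c(=O)n([C@H]2CO[C@@H](CO)C2)c2nc(N)nc(O)c21` gives 10% in this assay

Among the compounds with values here, compound 1 stands highest of the two numbers; compound 2 lies lower by a margin beyond the scatter, but the two differ in more than one place, so no single step links them. Compound 3 `COc1ccc(Cn2c(=O)n(C3OC(CO)[C@@H](O)[C@H]3O)c3nc(N)nc(O)c32)cc1` is still to be measured in this assay. It differs from compound 1 by 4-methoxyphenyl in place of 2-azido-1-hydroxyethyl on a saturated chain carbon bound to an aromatic nitrogen. Within the data shown here, no measured pair shows this change, so its size is open; a modest loss is expected, the estimated step of a number 21 percentage points lower from compound 1 to compound 3 (beyond the scatter) lying near the edge of the scatter. For compound 3 the expected value is 70%, range 30% to 100%.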

Compound 3, largest response reached (reported as maximal response), in percent of the reference or control that the assay uses: 44%
Compound 3: the middle estimate sits 26 percentage points above what was measured, within the range that was stated.
By their numbers in this assay, from the lowest: compound 2; then compound 3; then compound 1.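

In this assay, within the data shown here, 4-methoxyphenyl in place of 2-azido-1-hydroxyethyl on a saturated chain carbon bound to an aromatic nitrogen gives a number 47 percentage points lower from compound 1 to compound 3 (beyond the scatter), the first single-place comparison, and shows that the response depends on the group at this position. The response is reduced but not lost, with compound 3 at 44%. No measurement at hand accounts for the step.

As far as these compounds go, the change swaps the azido group, the hydroxyl and the aromatic ring at once, so which of them matters stays open. Also open, from the compounds shown here alone, is how a plain benzyl or a 3-aminopropyl chain would read here.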